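A few compounds are considered here, and "the series" means these few. Any claim that something is new, unique, unknown or untested is made for them only; others in the source may bear on it.

Compound 1, with structure `Cc1ccc(-c2ccc(F)cc2)n1-c1ccc(-c2nc3ccccc3s2)cc1`, is a cytotoxicity benchmark here: in a functional assay on MDA-MB-231 cells (Homo sapiens) for cytotoxicity, read by MTT assay, with a stated time of 72 h (a lower number here means a stronger inhibitor, a higher number a weaker inhibitor), compound 1 gives 11800 nM. Compound 2, with structure `COc1ccc(-c2ccc(C)n2-c2ccc(-c3nc4ccccc4s3)cc2)cc1`, differs from it in one place, (methoxy in place of fluoro on an aromatic carbon), and in this assay compound 2 gives 14800 nM. The step of a 1.3-fold higher number from compound 1 to compound 2 (0.10 log units; within the scatter) is therefore small, within the scatter of repeated measurements, so the two numbers cannot be told apart with confidence.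

Compound 3, with structure `Cc1ccc(-c2ccc(C)n2-c2ccc(-c3nc4ccc(F)cc4s3)cc2)cc1`, carries a different core from compound 1; the difference between the two cores is not broken down here. In this assay compound 3 gives 16700 nM, which stands within the scatter of both compound 1 and compound 2.

Compound 4, with structure `COc1ccc2nc(-c3ccc(-n4c(C)ccc4-c4ccc(C)cc4)cc3)sc2c1`, is not yet measured. It differs from compound 3 by methoxy in place of fluoro on an aromatic carbon. This is the same kind of change as from compound 1 to compound 2, but not the same: there the place was on an aromatic carbon of a six-membered aromatic ring of carbon only, para to a large group, whereas here the ring is part of a fused or bridged system of two rings, meta to a fused ring and para to a fused ring.

The step from compound 3 to compound 4 is expected to be about a 1.1-fold higher number from compound 3 to compound 4 (0.03 log units; within the scatter), resting on the earlier step of a 1.3-fold higher number from compound 1 to compound 2 (0.10 log units; within the scatter), which stayed within the scatter. Compound 4 is therefore estimated at 18000 nM, with a likely range from 8000 nM to 40000 nM.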

Compound 4, half-maximal inhibitory concentration: 20500 nM
Estimate against measurement, compound 4: 1.1-fold (0.06 log units) below, and the stated range covers the measured number.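

In this assay, putting methoxy in place of fluoro on the fused two-ring system gives a 1.2-fold higher number from compound 3 to compound 4 (0.09 log units; within the scatter), so this single step is too small to separate the two compounds. Set beside the same exchange on the aromatic ring of the core of compound 1, the step carries over from one core to the other with no detectable difference in size: the same change on two cores in this assay, a 1.3-fold higher number (0.10 log units; within the scatter) from compound 1 to compound 2 and a 1.2-fold higher number (0.09 log units; within the scatter) from compound 3 to compound 4, 1.0-fold (0.01 log units) apart, within the scatter of two such steps. This shows that, on these two cores and at these two places, the exchange of fluoro for methoxy left the number within the scatter, but it does not show that the exchange would do the same on a third core or at another place, and two small steps say nothing about why the number hardly moves.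

The compounds shown leave open whether any group at this place can shift the cytotoxicity number beyond the scatter, since only fluoro and methoxy appear there, and an amine, a carboxylic acid or a longer alkoxy chain such as butoxy might behave differently. On these data alone, it also remains open whether the match between the two cores would hold for such groups, or only for the exchange seen here.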